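A few compounds are considered here, and "the series" means these few. Any claim that something is new, unique, unknown or untested is made for them only; others in the source may bear on it.

Compound 3 `COc1ccc(CCOC2CC(=O)Nc3c2c(C)nn3-c2ncnc3nc[nH]c23)cc1` gives 2 nM in a functional assay on HEK293 cells for agonist activity at G-protein coupled receptor 39 (Homo sapiens), read by scintillation proximity assay and inositol phosphate accumulation, with a stated time of 75 min, in the presence of a further agent that is not named here (a lower number here means that less compound is needed, a higher number that more compound is needed for the effect), the lowest of the three numbers in hand; compound 1 `Cc1noc(C)c1COC1CC(=O)Nc2c1c(C)nn2-c1ncnc2nc[nH]c12` gives 5 nM and compound 2 `Cc1nn(-c2ncnc3nc[nH]c23)c2c1C(c1ccc(OC(C)C)cc1)CC(=O)N2` gives 18 nM. The steps of a 2.5-fold lower number from compound 1 to compound 3 (0.40 log units; beyond the scatter) and a 3.6-fold higher number from compound 1 to compound 2 (0.56 log units; beyond the scatter) both alter the substituent at this part of the shared core, and in each case a ring-bearing group is exchanged for another ring-bearing group. Compound 4 `Cc1nn(-c2ncnc3nc[nH]c23)c2c1C(OCC(C)C)CC(=O)N2` instead carries a smaller group: isopropyl in place of 4-methoxybenzyl on a saturated chain carbon bound to an oxygen on a saturated carbon. Among the measured compounds shown here, no measured step covers removal of the ring at this position, so the size of the effect is open, though the two recorded changes here each moved the number beyond the scatter. A modest rise is expected for compound 4, about 10 nM (range 3 nM to 40 nM), meaning a 5.0-fold higher number from compound 3 to compound 4 (0.70 log units; beyond the scatter).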

Compound 4, half-maximal effective concentration: 4 nM
For compound 4 the middle estimate is 2.5-fold (0.40 log units) above the measured one, within the range that was stated.
By their numbers in this assay, from the lowest: compounds 3, 4 and 1 (each within the scatter of the next, the first and the last beyond it); then compound 2.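

With isopropyl in place of 4-methoxybenzyl (a 2.0-fold higher number from compound 3 to compound 4 (0.30 log units; within the scatter)) or of 3,5-dimethyl-1,2-oxazol-4-yl (a 1.3-fold lower number from compound 1 to compound 4 (0.10 log units; within the scatter)), the number stays within the scatter, so a ring in this group is not required for a low number among compound 1, compound 3 and compound 4. Isobutoxy in place of 4-isopropoxyphenyl on a saturated ring carbon does move the number beyond the scatter (a 4.5-fold lower number from compound 2 to compound 4 (0.65 log units; beyond the scatter)). No supporting data explain either outcome. Going by these compounds, how far this tolerance extends remains open: an amine or a carboxylic acid at the end of the chain, or a longer chain, could hold the number or lose it.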